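A few compounds are considered here, and "the series" means these few. Any claim that something is new, unique, unknown or untested is made for them only; others in the source may bear on it.

Of the compounds shown here, two built on a shared core have been tested in a functional assay on SW-620 cells (Homo sapiens) for inhibition, read by sulforhodamine B assay, with a stated time of 48 h; on this read-out lower numbers stand for stronger inhibition of growth and higher numbers for weaker inhibition of growth. Compound 1 `O=C(Nc1cccc(-n2cc(-c3ccncc3)c(-c3ccc(Cl)c(O)c3)n2)c1)Nc1ccc(Cl)c(Cl)c1` carries a urea on its side arm. In this assay compound 1 reaches only a limit of the measurement, > 32500 nM. Compound 2 `COc1cc(-c2nn(-c3cccc(NC(=O)c4cccc(C(F)(F)F)c4)c3)cc2-c2ccncc2)ccc1Cl` carries an amide on the same arm. In this assay compound 2 likewise gives only a limit, > 50000 nM. Among the compounds with values here, compound 2 therefore stands at one of the two limits recorded, and with both known values being limits the limit of > 32500 nM in this assay, at which 1 of the 2 values shown sits (the limit of > 50000 nM in this assay, at which 1 of the 2 values shown sits), no step between measured compounds can be drawn. Compound 3 `COc1cc(-c2nn(-c3cccc(NC(=O)c4ccccc4)c3)cc2-c2ccncc2)ccc1Cl` differs from compound 2 in a single place: hydrogen in place of trifluoromethyl on an aromatic carbon. Within the data shown here, no measured step is available to guide the size of this change, so the expected step in this assay from compound 2 to compound 3 is none beyond the scatter, and compound 3 is expected to return a limit as well. The estimate for compound 3 in this assay is 50000 nM, with a range from 20000 nM to 100000 nM. The step this estimate means, a number no higher from compound 2 to compound 3 (the limit leaves the size open), is expected to stay within the scatter.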

Compound 3, concentration for total growth inhibition: > 100000 nM
Compound 3: no number, only a limit; the forecaster's own chance of this, stated with the estimate: 80%; middle value at least 2.0-fold (0.30 log units) away from the limit.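

In this assay compound 3 gives only a limit, > 100000 nM. Compound 2 also gives only a limit, so the step between compound 2 and compound 3 cannot be read. The compounds shown leave open what number any of the three would reach on this read-out, and whether hydrogen in place of trifluoromethyl changes it at all.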